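The compounds below may be only part of what the source reports. "The series", "measured", "known", "first", "only" and "open" are said of these compounds alone.

Measured compounds:
compound 1, `Cc1ccc(Cl)cc1Nc1nc(C(F)(F)F)ccc1CNC(=O)C(C)c1ccc(NS(C)(=O)=O)c(F)c1`, 14 nM 
compound 2, `CC1CCCN1c1nc(C(F)(F)F)ccc1CNC(=O)[C@@H](C)c1ccc(NS(C)(=O)=O)c(F)c1`, 0.3 nM 
compound 3, `C[C@H](C(=O)NCc1ccc(C(F)(F)F)nc1N1CC[C@@H](OCc2ccccc2)C1)c1ccc(NS(C)(=O)=O)c(F)c1`, 1.4 nM 

All three were tested in a functional assay on CHO-K1 cells for antagonist activity at transient receptor potential cation channel subfamily V member 1 (Homo sapiens), read by FLIPR; on this read-out lower numbers stand for stronger inhibition and higher numbers for weaker inhibition. Among these three numbers, compound 1 stands highest, which here means it is the weakest inhibitor of the set. Compound 3 is its nearest neighbour, lower and beyond the usual scatter; compound 2 lies furthest, lower still.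

The next compound, compound 4, has the structure `CC(C(=O)NCc1ccc(C(F)(F)F)nc1N1CCCCC1C)c1ccc(NS(C)(=O)=O)c(F)c1`. It differs from compound 1 in one place: 2-methylpiperidin-1-yl in place of (5-chloro-2-methylphenyl)amino on an aromatic carbon. A ring bearing an amino hydrogen is thus replaced by a saturated ring closed onto the nitrogen, so the hydrogen-bond donor is lost.

Within the data shown here, no measured pair shows exactly this exchange. Still, the two compounds that sit far below compound 1, compound 2 and compound 3, share a nitrogen-linked saturated ring in the same region rather than an anilino group. On that basis a clear drop in the number is expected for the step of a 9.3-fold lower number from compound 1 to compound 4 (0.97 log units; beyond the scatter), beyond the scatter. Compound 4 is therefore estimated at 1.5 nM, within a range of 0.3 nM to 8 nM.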

Compound 4, inhibition constant: 2.9 nM
Estimate against measurement, compound 4: 1.9-fold (0.29 log units) below; low and high end bracket the measured number.
By their numbers in this assay, from the lowest: compound 2; then compound 3; then compound 4; then compound 1.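

Replacing (5-chloro-2-methylphenyl)amino with 2-methylpiperidin-1-yl on the aromatic carbon next to the ring nitrogen gives, in this assay, a 4.8-fold lower number from compound 1 to compound 4 (0.68 log units; beyond the scatter). Among these compounds, this is the first comparison in which only this group changes, so it shows directly that strong inhibition at this position does not depend on the amino hydrogen or on the aromatic carbon ring of compound 1. No measurement here explains why the number falls.

The exchange removes the hydrogen-bond donor and replaces the aromatic ring with a non-aromatic one in a single step, so the compounds shown leave open which of these changes matters. They also leave open how a piperidin-1-yl group without the methyl, or a morpholin-4-yl group, would behave at this position.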